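The source may report more compounds than this note shows. Statements on the series, on what has been measured and on what is new or still open speak of the compounds shown alone.

Measured compounds:
Compound 1 `CCCN1C(=O)NC2(CSC3=C2C(=O)c2ccccc2C3=O)C1=O` gives 379 nM in a functional assay on SW-620 cells (Homo sapiens) for inhibition; on this read-out higher numbers stand for weaker inhibition and lower numbers for stronger inhibition.
Compound 2 `CCC(C)N1C(=O)NC2(CSC3=C2C(=O)c2ccccc2C3=O)C1=O` gives 562 nM in this assay.

On these two numbers compound 1 has the lowest value, and its nearest neighbour is compound 2, with a 1.5-fold higher number from compound 1 to compound 2 (0.17 log units; within the scatter). The two compounds therefore cannot be told apart on this read-out, and neither can be called the stronger inhibitor.

Compound 3 `CCN(CC)CCCN1C(=O)NC2(CSC3=C2C(=O)c2ccccc2C3=O)C1=O` is the next member of the series to be measured in this assay. It differs from compound 1 in one place: diethylamino in place of hydrogen on a saturated chain carbon, three bonds along the chain from an amide-type nitrogen in a ring. Going by the values given here, the only measured step that touches the chain on the ring nitrogen is the one from compound 1 to compound 2, a methyl added to the carbon bound to that nitrogen, and it produced a 1.5-fold higher number from compound 1 to compound 2 (0.17 log units; within the scatter), nothing beyond the scatter. Among the compounds with values here, no measured step adds a group at the far end of the propyl chain, so there is nothing to indicate a move in either direction. The expectation is that compound 3 stays close to compound 1, with a step of about a 1.2-fold higher number from compound 1 to compound 3 (0.07 log units; within the scatter), and the estimated value for compound 3 is 450 nM, in the range 150 nM to 1500 nM.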

Compound 3, half-maximal inhibitory concentration: 54 nM
Estimate against measurement, compound 3: 8.3-fold (0.92 log units) above, and the stated range ends above it.
By their numbers in this assay, from the lowest: compound 3; then compounds 1 and 2 (each within the scatter of the next).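

In this assay, the far end of the propyl chain on the ring nitrogen turns out to be a place where a change moves the number well beyond the scatter. Diethylamino in place of hydrogen there gives a 7.0-fold lower number from compound 1 to compound 3 (0.85 log units; beyond the scatter) and stands against the earlier methyl on the carbon bound to that nitrogen, which gave only a 1.5-fold higher number from compound 1 to compound 2 (0.17 log units; within the scatter) and so had suggested a flat read-out for this chain. Measured against the branched chain, 3-(diethylamino)propyl in place of sec-butyl on the same amide-type nitrogen gives a 10-fold lower number from compound 2 to compound 3 (1.02 log units; beyond the scatter), so the group carried on that nitrogen can shift the number widely, though nothing given here explains why this group does so.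

On these data alone, what remains open is whether the diethylamino group itself matters or any group at that chain end would do, which dimethylamino, a primary amine, a hydroxyl or a carboxylic acid in its place would help to settle. As far as these compounds go, it is also open how much the distance counts, since a shorter or a longer chain carrying the same diethylamino group could give a quite different number.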